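Methoxy for Methyl: Expecting Little Change in Potency

The compounds below may be only part of what the source reports. "The series", "measured", "known", "first", "only" and "open" are said of these compounds alone.

Of the compounds shown here, two have so far been measured in a functional assay on A549 cells (Homo sapiens) for antiproliferative activity, read by trypan blue exclusion, with a stated time of 24 h; on this read-out higher numbers stand for weaker inhibition and lower numbers for stronger inhibition. Compound 1 `O=C1NC(=O)/C(=C/c2cn(Cc3ccccc3)c3ccc(Cl)cc23)N1` gives 29700 nM in this assay, and compound 2 `Cc1ccc2c(c1)c(/C=C1\NC(=O)NC1=O)cn2Cc1ccccc1` gives 27700 nM. For the measured compounds named here, the single step connecting them, a 1.1-fold lower number from compound 1 to compound 2 (0.03 log units; within the scatter), lies within the scatter, so compound 2 holds the lower of the two numbers without standing apart from compound 1 in any meaningful way. Compound 3 `COc1ccc2c(c1)c(/C=C1\NC(=O)NC1=O)cn2Cc1ccccc1` has not yet been measured; it differs from compound 2 by methoxy in place of methyl on an aromatic carbon. Going by the values given here, no measured step exchanges methyl for methoxy, so the only guidance available is the exchange of chloro for methyl, a 1.1-fold lower number from compound 1 to compound 2 (0.03 log units; within the scatter), which barely moved the number. On that basis the author expects a step in this assay of about a 1.1-fold lower number from compound 2 to compound 3 (0.04 log units; within the scatter), that is, nothing beyond the scatter in either direction. Compound 3 is therefore estimated at 25000 nM in this assay, with a range from 8000 nM to 80000 nM that allows for the usual spread of such measurements.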

Compound 3, half-maximal inhibitory concentration: > 40000 nM
Compound 3 was reported as a limit; the forecaster's own chance of this, stated with the estimate: 10%; at least 1.6-fold (0.20 log units) between middle value and limit.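

In this assay the value of compound 3 is a limit and not a number: the limit of > 40000 nM in this assay, at which 1 of the 3 values shown sits. Methoxy in place of methyl on this aromatic carbon gives an at least 1.4-fold higher number from compound 2 to compound 3 (0.15 log units; that floor lies within the scatter), and methoxy in place of chloro gives an at least 1.3-fold higher number from compound 1 to compound 3 (0.12 log units; that floor lies within the scatter); these are floors only, so neither exchange is shown to go beyond the scatter, yet either may do so by an unknown amount. For the compounds shown here, the exchange of chloro for methyl gave a 1.1-fold lower number from compound 1 to compound 2 (0.03 log units; within the scatter), a step with both ends read, whereas methoxy gives the first change at this position with no upper end, so the position can no longer be taken as indifferent to the group it carries.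

The compounds shown leave open how far compound 3 truly lies from compound 1 and compound 2, and whether any real difference follows the oxygen of methoxy or simply its second heavy atom, which an ethyl group would help to separate. They also leave open what an amine or a hydroxyl group would do on this aromatic carbon, and whether any group here gives a number clearly lower than those of compound 1 and compound 2.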